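Formyl in place of methoxy on a breast-cancer cell assay

This account rests on a few compounds, and the source may have more. Where it says the series, first, only, none or still open, it means among the compounds named here.

Measured compounds:
compound 1 `c1ccc(-c2cn3ccnc3c(-c3ccc4ncn(C5CCCCC5)c4c3)n2)cc1`: 41.5%
compound 2 `COc1ccc(-c2cn3ccnc3c(-c3ccc4ncn(C5CCCCC5)c4c3)n2)cc1`: 71.1%

Both compounds were tested in a functional assay on MDA-MB-231 cells (Homo sapiens) for inhibition, read by sulforhodamine B assay, with a stated time of 48 h, tested at 10 uM; on this read-out lower numbers stand for less inhibition and higher numbers for more inhibition at the one concentration tested (going by the name of the read-out). In this assay compound 1 gives 41.5%, while compound 2 gives 71.1%, the higher of the two numbers shown. For the measured compounds named here, the only measured step, a number 29.6 percentage points higher from compound 1 to compound 2 (beyond the scatter), came from putting a methoxy in place of hydrogen on an aromatic carbon and lies beyond the scatter, so the group at this position matters for the read-out.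

Compound 3 `O=Cc1ccc(-c2cn3ccnc3c(-c3ccc4ncn(C5CCCCC5)c4c3)n2)cc1` is not yet measured. It differs from compound 2 in one place: formyl in place of methoxy on an aromatic carbon. Going by the values given here, no measured pair shows a formyl against a methoxy, so no step bears directly on this change. What the data do show is that this position responds to substitution, because a number 29.6 percentage points higher from compound 1 to compound 2 (beyond the scatter) was large. On these data alone, whether a formyl behaves like a methoxy or like hydrogen here is unknown, so the expected number for compound 3 is placed between the two measured values, with a wide range. The step is expected to be a number 19.1 percentage points lower from compound 2 to compound 3 (beyond the scatter). For compound 3 the estimated inhibition is 52%, expected to fall between 25% and 78%.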

Compound 3, a percentage reported as inhibition, at one concentration (the size of the read-out at that concentration, not a potency): 51.2%
For compound 3 the middle estimate is 0.8 percentage points above the measured one; the measured number falls inside the stated range.
By their numbers in this assay, from the lowest: compounds 1 and 3 (each within the scatter of the next); then compound 2.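

In this assay, putting formyl in place of methoxy gave a number 19.9 percentage points lower from compound 2 to compound 3 (beyond the scatter), so the higher number of compound 2 does not follow from simply having a group of this size here: methoxy and formyl have the same number of heavy atoms and of hydrogen-bond acceptors, yet they do not read alike. Putting formyl in place of hydrogen gave a number 9.7 percentage points higher from compound 1 to compound 3 (within the scatter), so at this one concentration the formyl compound cannot be told apart from the compound that carries only hydrogen. Among the three groups shown on this aromatic carbon, para to a large group, methoxy alone stands clearly apart from the other two, which means that a substituent here does not by itself guarantee a change in the read-out.

On these data alone, it remains open whether the higher number is special to methoxy or would also appear with an ethoxy, a hydroxyl or an amine in the same place. No outside evidence is at hand on the reason for the difference between methoxy and formyl.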